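Demethylation of a Benzyl Ether: Forecast for Compound 4

This account rests on a few compounds, and the source may have more. Where it says the series, first, only, none or still open, it means among the compounds named here.

Measured compounds in a functional assay on P388 cells (Mus musculus) for cytotoxicity; on this read-out higher numbers stand for weaker inhibition and lower numbers for stronger inhibition:
compound 1 `COc1ccc(Cc2cn(C3CC3)c3c(F)c(-c4cc(C)nc(C)c4)c(F)cc3c2=O)cc1`, 21000 nM
compound 2 `Cc1cc(-c2c(F)cc3c(=O)c(Cc4ccc[nH]4)cn(C4CC4)c3c2F)cc(C)n1`, 930 nM
compound 3 `COc1ccccc1Cc1cn(C2CC2)c2c(F)c(-c3cc(C)nc(C)c3)c(F)cc2c1=O`, 37000 nM

Compound 1 stands second highest of the three numbers. Its nearest neighbour is compound 3, a step of a 1.8-fold higher number from compound 1 to compound 3 (0.25 log units; within the scatter), which is within the scatter. The furthest is compound 2: the step is a 23-fold lower number from compound 1 to compound 2 (1.35 log units; beyond the scatter), the one large movement in the set, and it comes from swapping the whole 4-methoxyphenyl for 1H-pyrrol-2-yl on the saturated chain carbon bound to an aromatic carbon.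

Compound 4 is `Cc1cc(-c2c(F)cc3c(=O)c(Cc4ccc(O)cc4)cn(C4CC4)c3c2F)cc(C)n1`. Its difference from compound 1 is hydrogen in place of methyl on an oxygen on an aromatic ring. Among the measured compounds shown here, no measured step touches this methyl: the steps from compound 1 lead to compound 2 and compound 3 by exchanging the entire aryl group, not by trimming the methoxy to hydroxy. Compound 3 shows that moving the methoxy around the phenyl leaves the number where it was, while compound 2 shows that a different ring altogether can lower it strongly. A change confined to one methyl is closer in scale to the former. The estimate for compound 4 is therefore a step of a 1.4-fold lower number from compound 1 to compound 4 (0.15 log units; within the scatter), within or near the scatter, with the range left wide toward lower numbers. Compound 4 is expected to give about 15000 nM, between 4000 nM and 50000 nM.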

Compound 4, half-maximal inhibitory concentration: 1500 nM
Compound 4: the middle estimate sits 10-fold (1.00 log units) above what was measured, and the stated range ends above it.
By their numbers in this assay, from the lowest: compounds 2 and 4 (each within the scatter of the next); then compounds 1 and 3 (each within the scatter of the next).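

In this assay the methyl on the oxygen proves far from silent: trimming 4-methoxyphenyl to 4-hydroxyphenyl gives a 14-fold lower number from compound 1 to compound 4 (1.15 log units; beyond the scatter) and so removes only one carbon, whereas the earlier compounds had shown a large step only on exchanging the whole aryl group. The hydroxy compound also stands well apart from the 2-methoxyphenyl compound, with a 25-fold lower number from compound 3 to compound 4 (1.39 log units; beyond the scatter) on that exchange, while a 1.6-fold higher number from compound 2 to compound 4 (0.21 log units; within the scatter) leaves it level with the 1H-pyrrol-2-yl compound, so at this position a 4-hydroxyphenyl and a 1H-pyrrol-2-yl ring read alike and both methoxyphenyl compounds read alike. Nothing available here gives a measured reason for the size of this step or for that agreement.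

The compounds shown leave open whether the number follows the free hydroxy itself or simply the absence of the methyl, a question that an ethoxy, an amine or a carboxylic acid at the same place on the ring could help to settle. Also open, on these data alone, is whether trimming the methyl from the 2-methoxyphenyl of compound 3 would bring a step of similar size.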